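The compounds below may be only part of what the source reports. "The series", "measured", "known", "first", "only" and "open" are said of these compounds alone.

In a physicochemical assay for solubility, read by mass spectrometry, in phosphate buffer, with a stated time of 24 h, at pH 7.4 (a higher number here means a more soluble compound, a lower number a less soluble compound), compound 1 (`O=C(Nc1ccc(OC(F)(F)F)cc1)NC1CCN(C(=O)C2CCOCC2)CC1`) gives 91 ug/mL as the highest of the three numbers in hand. Compound 3 (`CC(C)C(=O)N1CCC(NC(=O)Nc2ccc(OC(F)(F)F)c(F)c2)CC1`) gives 5.3 ug/mL and compound 2 (`O=C(Nc1ccc(C(F)(F)F)cc1)NC1CCN(C(=O)[C@@H]2CCOC2)CC1`) gives 1.4 ug/mL as the two lower numbers, each beyond the scatter from compound 1. Compound 4 (`O=C(Nc1ccc(OC(F)(F)F)cc1)NC1CCN(C(=O)C2CCOC2)CC1`) has not yet been measured. It departs from compound 1 in one place, with oxolan-3-yl in place of oxan-4-yl on a carbonyl carbon. Among the compounds with values here, no measured pair shows this change alone. Within the data shown here, compound 2 also bears oxolan-3-yl, but no single-place step ties it to compound 1, so it offers only weak guidance. In this assay a modest fall is expected, close to the edge of the scatter, and the estimated move (a 2.0-fold lower number from compound 1 to compound 4 (0.31 log units; beyond the scatter)) is sized accordingly. Compound 4 is estimated at 45 ug/mL with an expected range of 12 ug/mL to 130 ug/mL until the measurement is in.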

Compound 4, solubility: 29 ug/mL
For compound 4 the middle estimate is 1.6-fold (0.19 log units) above the measured one; the range from low to high includes it.
By their numbers in this assay, from the lowest: compound 2; then compound 3; then compound 4; then compound 1.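

In this assay, within the data shown here, the first single-place step at this position, oxolan-3-yl in place of oxan-4-yl on a carbonyl carbon, gives a 3.1-fold lower number from compound 1 to compound 4 (0.50 log units; beyond the scatter). The earlier compounds shown here could not show this, since none of them differed from another in one place only. The step is modest yet beyond the scatter, so the swap from a six-membered to a five-membered non-aromatic ring, with one hetero atom in each, is enough to move the number here, and nothing in hand gives a reason for the move.

The compounds shown leave open whether the same swap gives a step of similar size on another aryl group, as no pair tests it with trifluoromethyl. They also leave open how the number would respond to a cyclohexyl ring without oxygen, or to an amine, on this carbonyl carbon.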